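Compound 1 to compound 4: a pyridin-2-yl exchange

This account rests on a few compounds, and the source may have more. Where it says the series, first, only, none or still open, it means among the compounds named here.

In a physicochemical assay for lipophilicity, read by HPLC, measured as chromatographic lipophilicity, at pH 7.4 (on this read-out higher numbers stand for higher lipophilicity and lower numbers for lower lipophilicity), compound 1 (`O=C(c1cnco1)N1CCC(C(=O)N2N=CC[C@H]2c2ccccc2)CC1`) gives 2.7. Compound 2 (`CC(C)(C)C(=O)N1N=CCC1c1cc[nH]n1`) gives 2.7, so the two stand level and share the lowest number of the three measured. Compound 3 (`CCC(=O)N1CCC(C(=O)N2N=CCC2c2ccccc2)CC1`) gives 3.2, beyond the scatter from the other two and the furthest from compound 1.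

Compound 4 (`O=C(C1CCN(c2ccccn2)CC1)N1N=CC[C@H]1c1ccccc1`) has pyridin-2-yl in place of (1,3-oxazol-5-yl)carbonyl on an amine nitrogen in a ring. Within the data shown here, no measured pair isolates this exchange, so the expectation rests on limited evidence. The nearest guide is compound 3 at 3.2, which has a different group at the same place and lacks the five-membered aromatic ring of compound 1. On that basis, an upward step beyond the scatter is expected in this assay. The estimated step is a number 0.90 log units higher from compound 1 to compound 4 (beyond the scatter). For compound 4, the estimated value is 3.6, with an expected range of 3.1 to 4.1.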

Compound 4, distribution coefficient: 5.1
The estimate for compound 4 lay 1.50 log units below the measured number, outside the stated range (above it).
By their numbers in this assay, from the lowest: compounds 1 and 2 (each within the scatter of the next); then compound 3; then compound 4.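

This position, on an amine nitrogen in a ring, now has its first readable step: in this assay, pyridin-2-yl in place of (1,3-oxazol-5-yl)carbonyl gives a number 2.40 log units higher from compound 1 to compound 4 (beyond the scatter), a large change. The exchange replaces a group of 7 heavy atoms and 3 hydrogen-bond acceptors with one of 6 heavy atoms and 1 hydrogen-bond acceptor, so the read-out moves strongly although the group size barely changes. No measurement available ties the step to any single feature of the exchange.

Among these compounds, the single pair leaves open whether the step follows the loss of the carbonyl or the change from a five-membered to a six-membered aromatic ring. A benzoyl group or a pyridine-2-carbonyl group on the same nitrogen would separate these two changes.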